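From a Pentyl Amide to a Pyridin-2-yl Amide

The source may report more compounds than this note shows. Statements on the series, on what has been measured and on what is new or still open speak of the compounds shown alone.

This account concerns three amides on a shared core, all tested in an ADME assay on MRC5 cells (Homo sapiens) for inhibition, with a stated time of 72 h; a higher number here means that more compound is needed for the effect, a lower number that less compound is needed. Compound 1 `COc1cccc(OC)c1C(=O)Nc1c[nH]nc1C(=O)NC1CCCCCC1` gives 42000 nM. Compound 2 `COc1cccc(OC)c1C(=O)Nc1c[nH]nc1C(=O)NN1CCOCC1` returns only a limit of the assay, > 50000 nM. Compound 3 `CCCCCNC(=O)c1n[nH]cc1NC(=O)c1c(OC)cccc1OC` likewise returns only a limit, > 50000 nM. Compound 3 thus stands at the limit of > 50000 nM in this assay, at which 2 of the 3 values shown sit, and no number for it is known. The measured steps leading to it are an at least 1.1-fold higher number from compound 1 to compound 3 (0.07 log units; that floor lies within the scatter) and a step that the two limits leave unreadable from compound 2 to compound 3, and the related step of an at least 1.1-fold higher number from compound 1 to compound 2 (0.07 log units; that floor lies within the scatter) is of the same kind. The unmeasured compound 4 `COc1cccc(OC)c1C(=O)Nc1c[nH]nc1C(=O)Nc1ccccn1` differs from compound 3 by pyridin-2-yl in place of pentyl on an amide-type nitrogen. Every measured step at this amide nitrogen either lies within the scatter or cannot be read, so no step beyond the scatter is expected for compound 4 in this assay. The step expected from this change is a number no higher from compound 3 to compound 4 (the limit leaves the size open). Compound 4 is therefore estimated at 50000 nM, within a range from 20000 nM to 100000 nM, and a limit rather than a number is considered quite possible.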

Compound 4, half-maximal effective concentration: > 50000 nM
Compound 4 was reported as a limit (the forecaster's own chance of this, stated with the estimate: 60%); the middle value sits exactly at the limit.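

In this assay, among these compounds, compound 4 also returns only a limit of the assay, so a six-membered aromatic ring with a hetero atom on this amide-type nitrogen ends in the same place as pentyl and morpholin-4-yl: the limit of > 50000 nM in this assay, at which 3 of the 4 values shown sit. The only step that can be read is an at least 1.1-fold higher number from compound 1 to compound 4 (0.07 log units; that floor lies within the scatter), and the steps among the three limits cannot be read. Across the pentyl, morpholin-4-yl and pyridin-2-yl groups, the change at this position has thus produced no number, and compound 1, with cycloheptyl, remains the exception as the only compound with one.

As far as these compounds go, how far compound 2, compound 3 and compound 4 lie past the limit stays open. From the compounds shown here alone, it also stays open whether a phenyl group or a cyclohexyl group on this nitrogen would give a number rather than a limit.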